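A Chloro Added to the Fluorophenyl Amide

A few compounds are considered here, and "the series" means these few. Any claim that something is new, unique, unknown or untested is made for them only; others in the source may bear on it.

Measured so far:
compound 1, `Nc1ccccc1NC(=O)c1ccc(CNC(=O)c2n[nH]cc2NC(=O)c2ccccc2F)cc1`: 6850 nM
compound 2, `O=C(NO)c1ccc(CNC(=O)c2n[nH]cc2NC(=O)c2ccccc2F)cc1`: 16700 nM

In a functional assay on SMMC-7721 cells (Homo sapiens) for inhibition, read by CCK-8 assay, with a stated time of 72 h (a lower number here means a stronger inhibitor, a higher number a weaker inhibitor), compound 1 gives 6850 nM, the lowest of the two numbers shown. Its nearest neighbour is compound 2, reached by the change of hydroxy in place of 2-aminophenyl on an amide-type nitrogen, a 2.4-fold higher number from compound 1 to compound 2 (0.39 log units; beyond the scatter). Compound 3, `Nc1ccccc1NC(=O)c1ccc(CNC(=O)c2n[nH]cc2NC(=O)c2c(F)cccc2Cl)cc1`, is not yet measured in this assay. It differs from compound 1 by chloro in place of hydrogen on an aromatic carbon, which, cut one bond further out, reads 2-fluorophenyl to 2-chloro-6-fluorophenyl. Going by the values given here, no measured step touches that ring: the only step available, a 2.4-fold higher number from compound 1 to compound 2 (0.39 log units; beyond the scatter), alters the far end of the shared core and carries no information about a chloro here. The expectation therefore rests on compound 1 alone, and the step from compound 1 to compound 3 is expected to stay within the scatter, a 1.1-fold lower number from compound 1 to compound 3 (0.06 log units; within the scatter). Compound 3 is estimated at 6000 nM, with a range from 2500 nM to 15000 nM.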

Compound 3, half-maximal inhibitory concentration: 16300 nM
Beside the measured number, compound 3's estimate is 2.7-fold (0.43 log units) below it, outside the stated range (above it).
By their numbers in this assay, from the lowest: compound 1; then compounds 3 and 2 (each within the scatter of the next).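

In this assay, the ring of the fluorophenyl amide proves to be a place where a single added atom registers: chloro in place of hydrogen on an aromatic carbon gives a 2.4-fold higher number from compound 1 to compound 3 (0.38 log units; beyond the scatter) and so weakens the compound modestly. Going by these compounds alone, this is the first measured change at this end of the molecule, as the earlier step, a 2.4-fold higher number from compound 1 to compound 2 (0.39 log units; beyond the scatter), altered the far end of the shared core. No measurement shown bears on the reason for the loss.

The compounds shown leave open whether the loss belongs to chloro itself or would also follow a methyl, a methoxy or a second fluoro at the same place. They also leave open whether the same chloro would weaken the hydroxy amide of compound 2 to a similar degree.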